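Replacing Phenyl by Hydrogen on the Five-Membered Ring

The source may hold more compounds than are shown below. What is called first, only, known or untested is meant among the compounds shown, and "the series" means these compounds.

Compound 1, `CCOC(=O)c1cnc(C(F)(F)F)nc1NN1C(=O)C=C(C)C1=O`, gives 1000 nM in a functional assay on Jurkat cells for inhibition of nuclear factor NF-kappa-B complex (Homo sapiens); a lower number here means a stronger inhibitor, a higher number a weaker inhibitor.
Compound 2, `CCOC(=O)c1cnc(C(F)(F)F)nc1NN1C(=O)C=C(c2ccccc2)C1=O`, gives 20000 nM in this assay.

Compound 2 has the higher of the two numbers and is thus the weaker inhibitor; the step to it was a 20-fold higher number from compound 1 to compound 2 (1.30 log units; beyond the scatter). Compound 3, `CCOC(=O)c1cnc(C(F)(F)F)nc1NN1C(=O)C=CC1=O`, carries hydrogen in place of phenyl on a double-bonded ring carbon. Going by the values given here, only one measured step bears on this change, the one that introduced the phenyl, and reversing that introduction suggests the number should fall back by a comparable amount, though methyl and hydrogen are not the same. Compound 3 is therefore expected to show a 13-fold lower number from compound 2 to compound 3 (1.12 log units; beyond the scatter), with an estimated value of 1500 nM in a range from 400 nM to 6000 nM.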

Compound 3, half-maximal inhibitory concentration: 10000 nM
Compound 3: the middle estimate sits 6.7-fold (0.82 log units) below what was measured; measured number above the stated range.
By their numbers in this assay, from the lowest: compound 1; then compounds 3 and 2 (each within the scatter of the next).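

Taking the phenyl off gives a 2.0-fold lower number from compound 2 to compound 3 (0.30 log units; within the scatter), while hydrogen in place of methyl gives a 10-fold higher number from compound 1 to compound 3 (1.00 log units; beyond the scatter). At this double-bonded ring carbon, the methyl of compound 1 is therefore what stands out, since hydrogen and phenyl cannot be separated in this measurement. No available evidence explains why methyl gives the lower number.

From the compounds shown here alone, whether the preference is specific to methyl remains open. An ethyl group, a longer chain or an amine at this carbon could match it or fall back towards hydrogen and phenyl.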